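The compounds below may be only part of what the source reports. "The series", "measured", "known", "first", "only" and "open" are said of these compounds alone.

Four closely related compounds are in view here, three of them already measured in an ADME assay (liver) for metabolic stability, with Liver microsome (Homo sapiens) as the target, using microsomes (a higher number here means faster removal of the compound, a lower number slower removal), and one still waiting. In this assay compound 1 `Cc1cnc(NC(=O)c2cc(Oc3ccc(S(C)(=O)=O)cc3)c3cc(C)oc3c2)cn1` returns a true number, 13 mL/min/kg on the scale of clearance. Compound 2 `CCN(C)C(=O)c1cnc(Oc2cc(C(=O)Nc3cnc(C)cn3)cc3oc(C)cc23)cn1` is reported only as a limit, < 8 mL/min/kg in that read-out. Compound 3 `Cc1cc2c(Oc3cnc(C(=O)N4CC(C)C4)cn3)cc(C(=O)Nc3cnccn3)cc2o1` is also reported only as a limit, < 9.6 mL/min/kg in that read-out, so its real position is not known. Compound 4 `Cc1cc2c(Oc3cnc(C(=O)N4CC(C)(C)C4)cn3)cc(C(=O)Nc3cnccn3)cc2o1` departs from compound 3 at a single point, where 3-methylazetidin-1-yl becomes 3,3-dimethylazetidin-1-yl, with methyl in place of hydrogen on a saturated ring carbon as the whole of the change. Within the data shown here, no measured pair in this small set isolates such a change, so nothing shows directly how a methyl at this place acts. The expectation therefore starts from the limit of compound 3 at < 9.6 mL/min/kg and allows only a modest shift. The expected change an at least 1.0-fold higher number from compound 3 to compound 4 (0.01 log units; that floor lies within the scatter) is small and, if anything, upward, and it is not expected to exceed the usual scatter. In this assay compound 4 is expected at 10 mL/min/kg within an estimated range from 6 mL/min/kg to 18 mL/min/kg for now.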

Compound 4, clearance: 21.2 mL/min/kg
Compound 4: middle estimate off by 2.1-fold (0.33 log units), on the low side; the measured number lies above the stated range.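

Among these compounds, the change from 3-methylazetidin-1-yl to 3,3-dimethylazetidin-1-yl is the first comparison in this set confined to a single place, and in this assay it gives an at least 2.2-fold higher number from compound 3 to compound 4 (0.34 log units; beyond the scatter). Among the compounds shown here, this position, on a saturated ring carbon two ring bonds from the ring nitrogen, is therefore not indifferent to one added methyl, something the earlier compounds, with no single-place pair among them, could not show. The full size of the step remains unknown because compound 3 is recorded only as a limit: the limit of < 9.6 mL/min/kg in this assay, at which 1 of the 4 values shown sits.

The compounds shown leave open whether this rise is particular to methyl, as a fluorine, a hydroxyl or a methoxy on the same ring carbon is not among them. Also open, on these data alone, is whether a larger ring amine, such as a pyrrolidine or a piperidine, in place of the azetidine in the amide of compound 4 would show a step of similar size.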